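A few compounds are considered here, and "the series" means these few. Any claim that something is new, unique, unknown or untested is made for them only; others in the source may bear on it.

In a functional assay on L1210 cells (Mus musculus) for antiproliferative activity, with a stated time of 48 h (a higher number here means a weaker inhibitor, a lower number a stronger inhibitor), compound 1 `C=C(Br)C(=O)Nc1ccc(/C=C/C(=O)c2ccc(F)cc2)cc1` gives 1600 nM and compound 2 `C=C(Br)C(=O)Nc1ccc(/C=C/C(=O)c2ccc(Br)cc2)cc1` gives 620 nM. Compound 3 `Nc1ccc(/C=C/C(=O)c2ccc(F)cc2)cc1` gives 123000 nM, the highest number of the three, which makes it the weakest inhibitor measured so far. It carries hydrogen in place of (1-bromoethenyl)carbonyl on a nitrogen on an aromatic ring, and the data show a 77-fold higher number from compound 1 to compound 3 (1.89 log units; beyond the scatter).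

Compound 4 `Nc1ccc(/C=C/C(=O)c2ccc(Br)cc2)cc1` has not yet been measured. It differs from compound 3 by bromo in place of fluoro on an aromatic carbon, para to a large group: bromo in place of fluoro on an aromatic carbon.

The same swap has been measured only once, in compounds that keep the (1-bromoethenyl)carbonyl group, where the data show a 2.6-fold lower number from compound 1 to compound 2 (0.41 log units; beyond the scatter). Going by the values given here, that single modest step is the only guide, and it may not carry over fully to compounds lacking that group. A similar modest drop is therefore expected, and the expected change is a 2.5-fold lower number from compound 3 to compound 4 (0.39 log units; beyond the scatter). The estimate for compound 4 is 50000 nM, with an expected range from 18000 nM to 130000 nM.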

Compound 4, half-maximal inhibitory concentration: 90000 nM
For compound 4 the middle estimate is 1.8-fold (0.26 log units) below the measured one, and the stated range covers the measured number.
By their numbers in this assay, from the lowest: compound 2; then compound 1; then compounds 4 and 3 (each within the scatter of the next).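

With hydrogen on the nitrogen in place of (1-bromoethenyl)carbonyl, bromo in place of fluoro gives only a 1.4-fold lower number from compound 3 to compound 4 (0.14 log units; within the scatter), so on this core the halogen swap shows no clear effect. Even so, the swap cannot be said to act differently on the two cores: the same change on two cores in this assay, a 2.6-fold lower number (0.41 log units; beyond the scatter) from compound 1 to compound 2 and a 1.4-fold lower number (0.14 log units; within the scatter) from compound 3 to compound 4, 1.9-fold (0.28 log units) apart, within the scatter of two such steps. The nitrogen change now has a second measurement, a 150-fold higher number from compound 2 to compound 4 (2.16 log units; beyond the scatter), and it is large with either halogen, matching the first within error: the same change on two cores in this assay, a 77-fold higher number (1.89 log units; beyond the scatter) from compound 1 to compound 3 and a 150-fold higher number (2.16 log units; beyond the scatter) from compound 2 to compound 4, 1.9-fold (0.28 log units) apart, within the scatter of two such steps.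

The compounds shown leave open whether a chloro or methoxy group at this aromatic carbon would shift the number any more than bromo does. They also leave open how much of the large step depends on the bromine of the nitrogen substituent, a question that an acetyl or plain propenoyl group on that nitrogen could address.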